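Moving the Fluorine on a Fluorophenyl Group

The compounds below may be only part of what the source reports. "The series", "measured", "known", "first", "only" and "open" are said of these compounds alone.

Measured in a functional assay on A2780 cells (Homo sapiens) for inhibition, read by sulforhodamine B assay, with a stated time of 72 h (a higher number here means a weaker inhibitor, a lower number a stronger inhibitor), so far:
- compound 1 `O=C(NCc1ccc(S(=O)(=O)c2cccc(F)c2)cc1)c1cc2cnccc2[nH]1` at 11 nM
- compound 2 `O=C(NCc1ccc(S(=O)(=O)N2CCCCC2)cc1)c1cc2ccncc2[nH]1` at 1700 nM
- compound 3 `O=C(NCc1ccc(S(=O)(=O)c2cc(F)cc(F)c2)cc1)c1cc2ccncc2o1` at 9 nM

Compound 1 (11 nM) lies within the scatter of compound 3 (9 nM), and both values are far lower than that of compound 2 (1700 nM). Compound 4 `O=C(NCc1ccc(S(=O)(=O)c2ccc(F)cc2)cc1)c1cc2cnccc2[nH]1` keeps the rest of compound 1 but differs in one group (4-fluorophenyl in place of 3-fluorophenyl on a sulfonyl sulfur), carrying 4-fluorophenyl in place of 3-fluorophenyl on a sulfonyl sulfur. Among the compounds with values here, no measured pair differs in a single place, so the expectation rests on the swap alone. The expected step in this assay, a 1.1-fold lower number from compound 1 to compound 4 (0.04 log units; within the scatter), is none beyond the scatter. Compound 4 is estimated at 10 nM, with an expected range of 3 nM to 30 nM for repeated measurements.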

Compound 4, half-maximal inhibitory concentration: 16 nM
Compound 4: the middle estimate sits 1.6-fold (0.20 log units) below what was measured; low and high end bracket the measured number.
By their numbers in this assay, from the lowest: compounds 3, 1 and 4 (each within the scatter of the next); then compound 2.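

Within the data shown here, this is the first pair that differs in one place: in this assay, 4-fluorophenyl in place of 3-fluorophenyl on a sulfonyl sulfur gives a 1.5-fold higher number from compound 1 to compound 4 (0.16 log units; within the scatter) on an otherwise unchanged compound. On this core, then, the two fluorine placements cannot be told apart in this assay. No measurement on hand bears on the reason for this.

The compounds shown leave open whether this tolerance extends beyond fluorine. A plain phenyl, a chlorophenyl or a methoxyphenyl on the same sulfonyl sulfur might read differently.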